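Swapping the trifluorinated end group of compound 2

A few compounds are considered here, and "the series" means these few. Any claim that something is new, unique, unknown or untested is made for them only; others in the source may bear on it.

In a functional assay on HCT-116 cells (Homo sapiens) for inhibition, read by colorimetric assay, with a stated time of 3 days (a higher number here means a weaker inhibitor, a lower number a stronger inhibitor), the measured compounds are these:
- compound 1 `O=C(CCCCCCNC(=O)C(O)(O)C(F)(F)F)Nc1ccc(F)cc1F` gives 18500 nM
- compound 2 `O=C(CCCCNC(=O)C(O)(O)C(F)(F)F)Nc1ccccc1` gives 20300 nM

Compound 2 at 20300 nM cannot be told apart from compound 1, as their two numbers lie within the usual scatter of repeated measurements.

Going by the values given here, compound 3 `NC(=O)C(=O)NCCCCC(=O)Nc1ccccc1` has no measurement yet. It differs from compound 2 in one place by carbamoyl in place of 2,2,2-trifluoro-1,1-dihydroxyethyl on a carbonyl carbon as the change, with carbamoyl in place of 2,2,2-trifluoro-1,1-dihydroxyethyl on a carbonyl carbon. Among the compounds with values here, both measured compounds carry the group that leaves, so no measured pair shows what its loss does, and the expectation rests on the structural change alone. A weaker inhibitor is expected, with a step beyond the scatter. The expected size is a 3.0-fold higher number from compound 2 to compound 3 (0.47 log units; beyond the scatter) towards a higher number. In this assay compound 3 is estimated at 60000 nM with 20000 nM to 200000 nM as the expected range.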

Compound 3, half-maximal inhibitory concentration: > 100000 nM
Compound 3: a limit, no number; the forecaster's own chance of this, stated with the estimate: 40%; middle value at least 1.6-fold (0.22 log units) from the limit.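

In this assay compound 3 gives > 100000 nM, which is a limit of the assay and not a number. Both earlier compounds carry the 2,2,2-trifluoro-1,1-dihydroxyethyl group, so they could not show whether this position tolerates a change; carbamoyl on this carbonyl carbon now gives an at least 4.9-fold higher number from compound 2 to compound 3 (0.69 log units; beyond the scatter). The true size of this step remains unknown, since only its lower bound can be read: the limit of > 100000 nM in this assay, at which 1 of the 3 values shown sits.

Going by these compounds, it remains open how a carboxylic acid or a plain methyl group on this carbonyl carbon would read, and whether the trifluoromethyl part or the two hydroxyl groups of the departing group account for the difference. Also open, on these data alone, is whether the same swap would have a similar result in the setting of compound 1.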